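A few compounds are considered here, and "the series" means these few. Any claim that something is new, unique, unknown or untested is made for them only; others in the source may bear on it.

Compound 1 `O=C(CN1CCC(c2cccc[n+]2[O-])CC1)Nc1cccc(F)c1`: 70%
Compound 2 `Cc1cc(Br)ccc1NC(=O)CN1CCC(c2cccc[n+]2[O-])CC1`: 61%
Compound 3 `O=C(CN1CCC(c2cccc[n+]2[O-])CC1)Nc1cccc(Cl)c1`: 76%

In a functional assay on HEK293 cells for agonist activity at D(4) dopamine receptor (Homo sapiens), read by FLIPR (a higher number here means a larger maximal response, a lower number a smaller maximal response), compound 3 gives 76%, the highest of the three numbers. The step of a number 6 percentage points higher from compound 1 to compound 3 (within the scatter) stays within the scatter, whereas a number 15 percentage points higher from compound 2 to compound 3 (beyond the scatter) lies beyond it, the 4-bromo-2-methylphenyl amide being the weaker of the pair.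

Compound 4 `Cc1cccc(C)c1NC(=O)CN1CCC(c2cccc[n+]2[O-])CC1` differs from compound 3 by 2,6-dimethylphenyl in place of 3-chlorophenyl on an amide-type nitrogen. The step that bears on this change is a number 15 percentage points higher from compound 2 to compound 3 (beyond the scatter), which shows the only other methyl-bearing anilide in the set at a modestly lower level; the step of a number 9 percentage points lower from compound 1 to compound 2 (within the scatter) points the same way but within the scatter. A modest decrease in this assay is therefore expected. Compound 4 is estimated to give 60%, between 45% and 76%, which would be a step of a number 16 percentage points lower from compound 3 to compound 4 (beyond the scatter).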

Compound 4, largest response reached (reported as efficacy), in percent of the reference or control that the assay uses: 68%
The estimate for compound 4 lay 8 percentage points below the measured number; the measured number falls inside the stated range.
By their numbers in this assay, from the lowest: compounds 2, 4, 1 and 3 (each within the scatter of the next, the first and the last beyond it).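

In this assay the change to 2,6-dimethylphenyl on an amide-type nitrogen gives a number 8 percentage points lower from compound 3 to compound 4 (within the scatter) and also a number 7 percentage points higher from compound 2 to compound 4 (within the scatter) and a number 2 percentage points lower from compound 1 to compound 4 (within the scatter) as its other steps. Compound 4 thus stays within the scatter of all three other anilides, so methyl groups on the ring do not by themselves bring a drop beyond the scatter. Nothing available here explains this result. Still open, on these data alone, is whether an amine or a carboxylic acid on this ring, or a longer chain in place of the methyl groups, would move the response beyond the scatter.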